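The compounds below may be only part of what the source reports. "The series", "measured", "known", "first", "only" and "open" are said of these compounds alone.

Measured so far in a functional assay on PC-3 cells (Homo sapiens) for cytotoxicity, read by MTT assay, with a stated time of 72 h; on this read-out higher numbers stand for weaker inhibition and lower numbers for stronger inhibition:
compound 1, `COc1ccc(/C=C/C(=O)/C=C/C2=C(C)CCCC2(C)C)cc1OC`, gives 42000 nM
compound 2, `CC1=C(/C=C/C(=O)/C=C/c2cccc(C(F)(F)F)c2)C(C)(C)CCC1`, gives 7700 nM
compound 3, `CC1=C(/C=C/C(=O)/C=C/c2ccc(C(F)(F)F)cc2)C(C)(C)CCC1`, gives 12000 nM

Compound 2 shows the lowest of the three numbers. Compound 3 sits within the usual scatter of it, so the two cannot be ordered, while compound 1 lies beyond the scatter with a clearly higher number. Compound 4, `CC1=C(/C=C/C(=O)/C=C/c2cc(C(F)(F)F)cc(C(F)(F)F)c2)C(C)(C)CCC1`, is not yet measured. It differs from compound 2 in one place: trifluoromethyl in place of hydrogen on an aromatic carbon. Among the measured compounds shown here, no measured pair shows this exact change, and both compounds carrying one trifluoromethyl give lower numbers than compound 1. A small step toward a lower number is expected, of about a 1.3-fold lower number from compound 2 to compound 4 (0.11 log units; within the scatter), hardly beyond the scatter. Compound 4 is therefore estimated at 6000 nM, with a range from 2500 nM to 15000 nM.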

Compound 4, half-maximal inhibitory concentration: 7200 nM
For compound 4 the middle estimate is 1.2-fold (0.08 log units) below the measured one, and the stated range covers the measured number.
By their numbers in this assay, from the lowest: compounds 4, 2 and 3 (each within the scatter of the next); then compound 1.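

In this assay the second trifluoromethyl on the aromatic ring gives a 1.1-fold lower number from compound 2 to compound 4 (0.03 log units; within the scatter) and so no measurable change at this position. Among the compounds shown here, this is the first direct reading of this change, as the earlier compounds differed in more than one place. No measurement here offers an explanation for the result. From the compounds shown here alone, whether a smaller group such as a fluorine atom, or an amine or a carboxylic acid, on this same aromatic carbon would move the number beyond the scatter stays open.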